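The source may hold more compounds than are shown below. What is called first, only, known or untested is meant among the compounds shown, and "the series" means these compounds.

Measured so far in a physicochemical assay for lipophilicity, using the shake flask method, measured as octanol-water partition, at pH 7.4; on this read-out lower numbers stand for lower lipophilicity and higher numbers for higher lipophilicity:
Compound 1 `CC(=O)N[C@H]1[C@H]([C@@H](O)[C@H](O)CNC(=O)c2ccc(Cl)cc2)O[C@@](OCc2ccccc2)(C(=O)O)C[C@@H]1O`: "not determined" (no result reported)
Compound 2 `CC(=O)N[C@H]1[C@H]([C@@H](O)[C@H](O)CNC(=O)c2ccc(Cl)cc2)O[C@@](OCc2c(F)c(F)c(F)c(F)c2F)(C(=O)O)C[C@@H]1O`: -0.11

For the measured compounds named here, compound 2 holds the only number, so it cannot yet be ranked against anything. Next is compound 3 `CC(=O)N[C@H]1[C@H]([C@@H](O)[C@H](O)CNC(=O)c2ccc(Cl)cc2)O[C@@](OCc2cccc(Cl)c2Cl)(C(=O)O)C[C@@H]1O`, which carries 2,3-dichlorophenyl in place of 2,3,4,5,6-pentafluorophenyl on a saturated chain carbon bound to an oxygen on a saturated carbon. Going by the values given here, no measured step supports a prediction, so the expectation rests on the structural change alone. A small rise in this assay, modestly beyond the scatter, is expected. The estimated step is a number 0.36 log units higher from compound 2 to compound 3 (beyond the scatter). Compound 3 is expected at 0.25, within an estimated range of -0.2 to 0.7.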

Compound 3, distribution coefficient: 0.53
Beside the measured number, compound 3's estimate is 0.28 log units below it, within the range that was stated.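

In this assay, for the compounds shown here, this position on a saturated chain carbon bound to an oxygen on a saturated carbon responds to the aryl group: 2,3-dichlorophenyl in place of 2,3,4,5,6-pentafluorophenyl gives a number 0.64 log units higher from compound 2 to compound 3 (beyond the scatter), the first readable step. Both groups carry no hydrogen-bond donors or acceptors and no net charge, so the step arises without a change in those counts. Nothing available accounts for the size of this step. Still open, as far as these compounds go, is how a nitrile or a carboxylic acid on the aromatic ring, or a longer chain at this place, would register on this read-out.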